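Halogen swap on a shared core: chloro to fluoro

This account rests on a few compounds, and the source may have more. Where it says the series, first, only, none or still open, it means among the compounds named here.

Measured compounds:
Compound 1, `Brc1ccc(C2=NN(C3=NC(c4ccccc4)CS3)C(c3ccc4ccccc4c3)C2)cc1`, gives 13000 nM.
Compound 2, `O=C1CSC(N2N=C(c3ccc(Cl)cc3)CC2c2ccc3ccccc3c2)=N1`, gives 13200 nM.
Compound 3, `Clc1ccc(C2=NN(C3=NC(c4ccccc4)CS3)C(c3ccc4ccccc4c3)C2)cc1`, gives 14600 nM.

All three values come from a functional assay on BGC-823 cells (Homo sapiens) for inhibition, read by CCK-8 assay, with a stated time of 48 h; a higher number here means a weaker inhibitor, a lower number a stronger inhibitor. Compound 3 has the highest number of the three, but the step of a 1.1-fold higher number from compound 2 to compound 3 (0.04 log units; within the scatter) and the step of a 1.1-fold higher number from compound 1 to compound 3 (0.05 log units; within the scatter) both lie within the scatter, so the three compounds cannot be told apart on these numbers.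

Compound 4, `Fc1ccc(C2=NN(C3=NC(c4ccccc4)CS3)C(c3ccc4ccccc4c3)C2)cc1`, has not yet been measured. It differs from compound 3 in one place: fluoro in place of chloro on an aromatic carbon.

Among the compounds with values here, the only measured step that bears on this change is the one from bromo to chloro at the same place, a 1.1-fold higher number from compound 1 to compound 3 (0.05 log units; within the scatter), which was within the scatter. A second halogen swap at that position, chloro to fluoro, is therefore expected to move this assay little, if at all, in either direction; the step of a 1.0-fold lower number from compound 3 to compound 4 (0.02 log units; within the scatter) is expected to stay within the scatter. Compound 4 is thus estimated at 14000 nM, with a range from 7000 nM to 28000 nM.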

Compound 4, half-maximal inhibitory concentration: 17300 nM
Compound 4: middle estimate off by 1.2-fold (0.09 log units), on the low side; measured number inside the range.
By their numbers in this assay, from the lowest: compounds 1, 2, 3 and 4 (each within the scatter of the next).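

In this assay, this aromatic carbon has now carried bromo, chloro and fluoro, and both the step of a 1.2-fold higher number from compound 3 to compound 4 (0.07 log units; within the scatter) and the step of a 1.3-fold higher number from compound 1 to compound 4 (0.12 log units; within the scatter) stay within the scatter. The earlier compounds shown here showed this for bromo and chloro alone; adding fluoro extends it, so the three halogens at this position cannot be told apart on these numbers. Nothing available offers an explanation for how closely these values agree.

The compounds shown leave open whether a non-halogen group at this place, such as a methoxy, an amine or a carboxylic acid, would move the number beyond the scatter. They also leave open whether fluoro in place of chloro would read the same with the different ring that compound 2 carries on its amine nitrogen.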